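From phenethyl to 2,5-dichlorobenzyl on the sulfur

The source may report more compounds than this note shows. Statements on the series, on what has been measured and on what is new or still open speak of the compounds shown alone.

Measured in a functional assay on BGC-823 cells (Homo sapiens) for inhibition, read by MTT assay, with a stated time of 72 h; on this read-out higher numbers stand for weaker inhibition and lower numbers for stronger inhibition:
- compound 1 `Cc1cc(N2CC[C@@H](C)[C@@H](N(C)c3ncnc4[nH]ccc34)C2)n2nc(SCc3ccc(Cl)cc3)nc2n1`: 26300 nM
- compound 2 `Cc1cc(N2CC[C@@H](C)[C@@H](N(C)c3ncnc4[nH]ccc34)C2)n2nc(SCc3csc4ccc(Cl)cc34)nc2n1`: > 100000 nM, a limit of the assay and not a number
- compound 3 `Cc1cc(N2CC[C@@H](C)[C@@H](N(C)c3ncnc4[nH]ccc34)C2)n2nc(SCCc3ccccc3)nc2n1`: 28000 nM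

The two true numbers sit together, and the only gap between them is a 1.1-fold higher number from compound 1 to compound 3 (0.03 log units; within the scatter). So compound 3 stands level with compound 1, and neither can be ranked above the other. The entry with the limit stands apart, as an at least 3.5-fold lower number from compound 2 to compound 3 (0.55 log units; beyond the scatter) shows.

Compound 4 `Cc1cc(N2CC[C@@H](C)[C@@H](N(C)c3ncnc4[nH]ccc34)C2)n2nc(SCc3cc(Cl)ccc3Cl)nc2n1` has not yet been measured. It differs from compound 3 in one place: 2,5-dichlorophenyl in place of benzyl on a saturated chain carbon bound to a sulfur. In words, this is 2,5-dichlorophenyl in place of benzyl on a saturated chain carbon bound to a sulfur.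

Two measured steps at this same place bear on the change. One is a 1.1-fold higher number from compound 1 to compound 3 (0.03 log units; within the scatter), which shows that a change here need not move the number. The other is an at least 3.8-fold higher number from compound 1 to compound 2 (0.58 log units; beyond the scatter), which shows that it sometimes can. The 2,5-dichlorophenyl group most resembles the 4-chlorophenyl of compound 1, so no step beyond the scatter is expected in this assay, though a drift towards higher numbers remains possible. The expected step is a 1.2-fold higher number from compound 3 to compound 4 (0.07 log units; within the scatter).

For compound 4 the estimated value is 33000 nM, with an expected range from 12000 nM to 90000 nM.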

Compound 4, half-maximal inhibitory concentration: 18900 nM
Compound 4: middle estimate off by 1.7-fold (0.24 log units), on the high side; measured number inside the range.
By their numbers in this assay, from the lowest: compounds 4, 1 and 3 (each within the scatter of the next). At a limit, above all of these: compound 2.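

In this assay, the 2,5-dichlorophenyl group gives a 1.5-fold lower number from compound 3 to compound 4 (0.17 log units; within the scatter), and set against the 4-chlorophenyl it gives a 1.4-fold lower number from compound 1 to compound 4 (0.14 log units; within the scatter), so neither change moves the number beyond the scatter. This position therefore accepts a single benzene ring with no chlorine, one chlorine or two chlorines, on a one-carbon or two-carbon link to the sulfur, with no measurable separation among compounds 1, 3 and 4; compound 2 is the one entry that goes against this, as an at least 5.2-fold lower number from compound 2 to compound 4 (0.72 log units; beyond the scatter) shows. That step is only a bound, since the entry for compound 2 is a limit of the assay and not a number: the limit of > 100000 nM in this assay, at which 1 of the 4 values shown sits.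

The compounds shown cannot say whether the fused ring system of compound 2, its sulfur or the place of its chlorine sets it apart, and a plain naphthyl group on the same chain carbon would help to separate these. Going by these compounds, how an amine, a carboxylic acid or a chain longer than phenethyl would behave on this sulfur also remains open.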